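This account rests on a few compounds, and the source may have more. Where it says the series, first, only, none or still open, it means among the compounds named here.

In a physicochemical assay for solubility, using the shake flask method, measured as thermodynamic solubility, with a stated time of 2 h, at pH 6.5 (a lower number here means a less soluble compound, a higher number a more soluble compound), compound 1 `O=[N+]([O-])c1ccc2c(ccn2-c2ccc(O[C@H]3O[C@H](CO)[C@@H](O)[C@H](O)[C@@H]3O)c(Cl)c2)c1` gives 1.4 ug/mL as its reading. Compound 2 `OC[C@H]1O[C@H](Oc2ccc(-n3ccc4ccccc43)cc2F)[C@@H](O)[C@@H](O)[C@@H]1O` gives 67 ug/mL and holds the higher of the two numbers, with the gap beyond the scatter. For the measured compounds named here, compound 3 `O=[N+]([O-])c1ccc2c(ccn2-c2ccc(O[C@H]3O[C@H](CO)[C@@H](O)[C@H](O)[C@@H]3O)c(F)c2)c1` is compound 2 with nitro in place of hydrogen on an aromatic carbon and no measured step isolates this change. Compound 1 also carries nitro, stands at 1.4 ug/mL and so points to an expected lower number, beyond the scatter. The expected size is the step of a 17-fold lower number from compound 2 to compound 3 (1.22 log units; beyond the scatter) as estimated here. Compound 3 is estimated at 4 ug/mL with a range from 1 ug/mL to 15 ug/mL expected.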

Compound 3, solubility: 4 ug/mL
For compound 3 middle estimate and measured number coincide at the digits printed; low and high end bracket the measured number.
By their numbers in this assay, from the lowest: compound 1; then compound 3; then compound 2.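

In this assay, nitro in place of hydrogen on an aromatic carbon now has a directly measured step with fluoro held constant: a 17-fold lower number from compound 2 to compound 3 (1.22 log units; beyond the scatter). With nitro held constant, fluoro in place of chloro on an aromatic carbon gives a 2.9-fold higher number from compound 1 to compound 3 (0.46 log units; beyond the scatter), so the halogen also shifts the reading. No measured data on hand explain either step.

As far as these compounds go, whether an amine or a nitrile on the same carbon would read like nitro remains open. Each step is also read on a single background: nitro in place of hydrogen only with fluoro present, and fluoro in place of chloro only with nitro present.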